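Chloro for bromo across two cores

The source may report more compounds than this note shows. Statements on the series, on what has been measured and on what is new or still open speak of the compounds shown alone.

Compound 1 `O=C(NS(=O)(=O)c1ccc(Br)cc1)c1cncc(Br)c1` and compound 2 `O=C(NS(=O)(=O)c1ccc(Cl)cc1)c1cncc(Br)c1` share one core and differ in a single place: chloro in place of bromo on an aromatic carbon. In a functional assay on MCF7 cells (Homo sapiens) for antiproliferative activity, read by MTT assay, with a stated time of 48 h (on this read-out higher numbers stand for weaker inhibition and lower numbers for stronger inhibition), compound 1 gives 340 nM. In this assay compound 2 gives 70 nM. The step between them is a 4.9-fold lower number from compound 1 to compound 2 (0.69 log units; beyond the scatter).

Compound 3 `O=C(NS(=O)(=O)c1ccc(Br)cc1)c1cccnc1Cl` is built on a different core. How this core differs from that of compound 1 is not broken down here. In this assay compound 3 gives 11400 nM, the highest number of the three measured compounds, and its gap to compound 1 and to compound 2 is beyond the scatter in both cases.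

Compound 4 `O=C(NS(=O)(=O)c1ccc(Cl)cc1)c1cccnc1Cl` has not been measured. It differs from compound 3 by chloro in place of bromo on an aromatic carbon. This is the same change as the one made from compound 1 to compound 2, at the same place, and it occurs twice among the compounds shown.

For compound 4 the step in this assay is expected to be a 4.6-fold lower number from compound 3 to compound 4 (0.66 log units; beyond the scatter), set beside the earlier one, a 4.9-fold lower number from compound 1 to compound 2 (0.69 log units; beyond the scatter). This rests on that single measured pair only; whether the change carries over to the second core is not known from the data, so the expectation is held loosely and the range is kept wide.

Compound 4 is expected to give about 2500 nM in this assay, estimated within 800 nM to 8000 nM.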

Compound 4, half-maximal inhibitory concentration: 10200 nM
For compound 4 the middle estimate is 4.1-fold (0.61 log units) below the measured one, and the stated range ends below it.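

Chloro in place of bromo on an aromatic carbon does not behave the same way on the core of compound 3 in this assay, where it gives a 1.1-fold lower number from compound 3 to compound 4 (0.05 log units; within the scatter). The step seen on the core of compound 1 therefore does not transfer in size to the second core, and the two steps differ by more than repeat measurements would explain: the same change on two cores in this assay, a 4.9-fold lower number (0.69 log units; beyond the scatter) from compound 1 to compound 2 and a 1.1-fold lower number (0.05 log units; within the scatter) from compound 3 to compound 4, 4.3-fold (0.64 log units) apart, beyond the scatter of two such steps. This shows that, within these two matched pairs, the effect of the change depends on the core, so a step measured on one core is a poor guide to the other; it does not show which feature of the core is responsible, nor how the change would behave on any further core.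

The compounds shown leave open how another group at the same place, such as a methoxy group or an amine, would read on either core, and whether that step would also depend on the core. They also leave open whether a third core would follow the pair of compound 1 and compound 2 or the pair of compound 3 and compound 4.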